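Furan-2-yl in Place of 4-Chlorophenyl: What to Expect

The compounds below may be only part of what the source reports. "The series", "measured", "known", "first", "only" and "open" are said of these compounds alone.

Compound 1 `Cc1ccsc1-c1ncnc2c1ncn2C1O[C@H](CO)[C@@H](O)[C@H]1O`: in a functional assay on HeLa cells (Homo sapiens) for inhibition (on this read-out higher numbers stand for weaker inhibition and lower numbers for stronger inhibition), compound 1 reaches only the limit of > 20000 nM.
Compound 2 `OC[C@H]1OC(n2cnc3c(-c4ccc(Cl)cc4)ncnc32)[C@H](O)[C@@H]1O`: in this assay compound 2 gives 5000 nM.

Compound 2 therefore holds the only real number shown; the other entry is a limit, not a number (the limit of > 20000 nM in this assay, at which 1 of the 2 values shown sits). Compound 3 `OC[C@H]1OC(n2cnc3c(-c4ccco4)ncnc32)[C@H](O)[C@@H]1O` is still to be measured in this assay, and it differs from compound 2 in one place: furan-2-yl in place of 4-chlorophenyl on an aromatic carbon.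

Within the data shown here, only one measured step touches the same position, an at least 4.0-fold lower number from compound 1 to compound 2 (0.60 log units; beyond the scatter), and it ran toward stronger inhibition when 3-methylthiophen-2-yl gave way to 4-chlorophenyl. Furan-2-yl stands closer in kind to 3-methylthiophen-2-yl than to 4-chlorophenyl, so the step from compound 2 to compound 3 is expected to run back the other way, by a modest amount beyond the scatter, with a fair chance that only a limit is reported. Compound 3 is therefore estimated at 15000 nM, between 4000 nM and 40000 nM, an expected step of a 3.0-fold higher number from compound 2 to compound 3 (0.48 log units; beyond the scatter).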

Compound 3, half-maximal inhibitory concentration: 25000 nM
For compound 3 the middle estimate is 1.7-fold (0.22 log units) below the measured one, within the range that was stated.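

In this assay, furan-2-yl in place of 4-chlorophenyl brings a 5.0-fold higher number from compound 2 to compound 3 (0.70 log units; beyond the scatter), which gives this position its first real number for a group with a five-membered aromatic ring. Among the compounds shown, 4-chlorophenyl in compound 2 is now the only group at this position with a value under the read-out's limit, and neither five-membered group, the 3-methylthiophen-2-yl of compound 1 or the furan-2-yl of compound 3, goes against that picture. The two five-membered groups still cannot be ranked against each other, and the step between compound 1 and compound 3 cannot be read, because compound 1 stands at a limit and not at a number: the limit of > 20000 nM in this assay, at which 1 of the 3 values shown sits.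

The compounds shown leave open whether the chlorine or the six-membered aromatic ring of carbon carries the difference, a question that a plain phenyl group at this position would address directly. They also leave open how far the value of compound 2 could move with an amine or a carboxylic acid on that phenyl ring in place of the chlorine.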